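A benzyl group replaces butyl in compound 3

The source may report more compounds than this note shows. Statements on the series, on what has been measured and on what is new or still open speak of the compounds shown alone.

In a functional assay for inhibition, with Homo sapiens as the target (on this read-out lower numbers stand for stronger inhibition and higher numbers for weaker inhibition), compound 1 `CS(=O)(=O)N[C@@H](CNC(=O)c1ccc2c(c1)C(=O)N(CCC1CCNCC1)C2)C(=O)O` gives 14 nM, compound 2 `CCCCCS(=O)(=O)N[C@@H](CNC(=O)c1ccc2c(c1)C(=O)N(CCC1CCNCC1)C2)C(=O)O` gives 9 nM and compound 3 `CCCCNC(=O)N[C@@H](CNC(=O)c1ccc2c(c1)C(=O)N(CCC1CCNCC1)C2)C(=O)O` gives 16 nM. These values lie within the usual scatter of one another, so compound 3 cannot be separated from either of the others. Compound 4 `O=C(NCc1ccccc1)N[C@@H](CNC(=O)c1ccc2c(c1)C(=O)N(CCC1CCNCC1)C2)C(=O)O` carries one change from compound 3: phenyl in place of propyl on a saturated chain carbon bound to an amide-type nitrogen, with phenyl in place of propyl on a saturated chain carbon bound to an amide-type nitrogen. The measured side-chain changes all stayed within the scatter: a 1.6-fold lower number from compound 1 to compound 2 (0.19 log units; within the scatter), a 1.1-fold higher number from compound 1 to compound 3 (0.06 log units; within the scatter) and a 1.8-fold higher number from compound 2 to compound 3 (0.25 log units; within the scatter). As far as these compounds go, none of them introduces a ring, so that remains untested. No shift beyond the scatter is expected, and the estimated change is a 1.1-fold lower number from compound 3 to compound 4 (0.06 log units; within the scatter). The expected value for compound 4 is 14 nM, within an estimated range of 6 nM to 35 nM.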

Compound 4, half-maximal inhibitory concentration: 10 nM
Compound 4: the middle estimate sits 1.4-fold (0.15 log units) above what was measured; low and high end bracket the measured number.
By their numbers in this assay, from the lowest: compounds 2, 4, 1 and 3 (each within the scatter of the next).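

In this assay, the butylcarbamoyl chain of compound 3 can carry a six-membered aromatic ring in place of propyl without a shift beyond the scatter (a 1.6-fold lower number from compound 3 to compound 4 (0.20 log units; within the scatter)). The benzylcarbamoyl group also stays within the scatter of both sulfonyl groups (a 1.1-fold higher number from compound 2 to compound 4 (0.05 log units; within the scatter); a 1.4-fold lower number from compound 1 to compound 4 (0.15 log units; within the scatter)). No measurement given here explains this result. As far as these compounds go, a phenyl ring carrying an amine or a carboxylic acid remains open, as does a phenethyl group in place of benzyl.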